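A longer tether on compound 2, toward compound 4

The source may report more compounds than this note shows. Statements on the series, on what has been measured and on what is new or still open speak of the compounds shown alone.

Measured so far:
compound 1 `O=C(CI)NCCCCCCC(=O)NCCCCCCNc1ncnc2c1ncn2[C@@H]1O[C@H](COP(=O)(O)OP(=O)(O)OP(=O)(O)O)[C@@H](O)[C@H]1O` gives 0%
compound 2 `CN(CCCCN(C)c1ncnc2c1ncn2[C@@H]1O[C@H](COP(=O)(O)OP(=O)(O)OP(=O)(O)O)[C@@H](O)[C@H]1O)C(=O)CCCNC(=O)CI` gives 0%
compound 3 `O=C(CI)NCCC(=O)NCCCCCCNc1ncnc2c1ncn2[C@@H]1O[C@H](COP(=O)(O)OP(=O)(O)OP(=O)(O)O)[C@@H](O)[C@H]1O` gives 0%

All three values come from an assay on isolated protein for inhibition of hexokinase-1 (Rattus norvegicus), with a stated time of 6 h, tested at 10 mM; a higher number here means more inhibition at the concentration tested (going by the name of the read-out), a lower number less inhibition. On that read-out compound 2 stands level with compounds 1 and 3: none of the three shows any inhibition at the single concentration tested, and the gaps between them lie within the usual scatter. Compound 4 `CN(CCCCN(C)c1ncnc2c1ncn2[C@@H]1O[C@H](COP(=O)(O)OP(=O)(O)OP(=O)(O)O)[C@@H](O)[C@H]1O)C(=O)CCCCCNC(=O)CI` has not yet been measured. It differs from compound 2 in one place: 2-(((iodomethyl)carbonyl)amino)ethyl in place of ((iodomethyl)carbonyl)amino on a saturated chain carbon, three bonds along the chain from a carbonyl carbon. Among the compounds with values here, the only measured step that speaks to such a change is the one between compounds 1 and 3, which also alters the length of the chain carrying the ((iodomethyl)carbonyl)amino group, and that step gave no change at the digits printed from compound 1 to compound 3 (within the scatter). Within the data shown here, with every measured compound at the same level and the one comparable step showing no change, the expectation for compound 4 is that the step of no change at the digits printed from compound 2 to compound 4 (within the scatter) stays within the scatter. Compound 4 is therefore estimated at 0%, with a likely range from 0% to 10%.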

Compound 4, a percentage reported as inhibition, at one concentration (the size of the read-out at that concentration, not a potency): 0%
For compound 4 middle estimate and measured number coincide at the digits printed; low and high end bracket the measured number.
By their numbers in this assay, from the lowest: compounds 1, 2, 3 and 4 (each within the scatter of the next).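

In this assay, placing 2-(((iodomethyl)carbonyl)amino)ethyl in place of ((iodomethyl)carbonyl)amino, on a saturated chain carbon three bonds along the chain from a carbonyl carbon, leaves the read-out as it was (no change at the digits printed from compound 2 to compound 4 (within the scatter)). Changing the chain length on compound 2 therefore matches what the pair without methyl groups on its amide and amine nitrogens already showed (no change at the digits printed from compound 1 to compound 3 (within the scatter)), so this absence of a change now appears in two related pairs, though compound 4 still shows no inhibition (0%) and the step therefore reveals no gain or loss from a measurable level. No other measurement here bears on this result, and it offers no explanation for it.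

The compounds shown leave open whether a longer chain still would give any inhibition at this position. They also leave open whether replacing the ((iodomethyl)carbonyl)amino end with a ((chloromethyl)carbonyl)amino group or a simple amine would change the read-out.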